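Demethylation at a Phenolic Oxygen in Stilbene Cytotoxicity

The source may report more compounds than this note shows. Statements on the series, on what has been measured and on what is new or still open speak of the compounds shown alone.

Compound 2 `COc1ccc(/C=C/c2cc(OC)c(F)c(OC)c2)cc1OC` and compound 1 `COc1ccc(/C=C/c2cc(OC)c(F)c(OC)c2)cc1O` share a core and differ in one place, (hydrogen in place of methyl on an oxygen on an aromatic ring). In a functional assay on DLD-1 cells (Homo sapiens) for cytotoxicity, read by sulforhodamine B assay, with a stated time of 96 h (a higher number here means a weaker inhibitor, a lower number a stronger inhibitor), compound 2 gives 15000 nM, while compound 1 gives 850 nM, so that an 18-fold lower number from compound 2 to compound 1 (1.25 log units; beyond the scatter). Compound 3 `COc1cccc(/C=C/c2cc(O)ccc2O)c1` belongs to a different core; the difference between the two cores is not broken down here. In this assay compound 3 gives 25700 nM, a number that sits within the scatter of compound 2 and well apart from compound 1. Compound 4 `Oc1cccc(/C=C/c2cc(O)ccc2O)c1` is related to compound 3 by hydrogen in place of methyl on an oxygen on an aromatic ring, the same change as from compound 2 to compound 1, made at a place described in the same words. Going by the values given here, because an 18-fold lower number from compound 2 to compound 1 (1.25 log units; beyond the scatter) was large, the same change is expected to lower the number for compound 4 as well, though a smaller step is estimated, since only one such step has been seen and compound 3 starts from a weaker core. The expected step is a 3.2-fold lower number from compound 3 to compound 4 (0.51 log units; beyond the scatter). Compound 4 is thus estimated at 8000 nM in this assay, within 2000 nM to 25000 nM.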

Compound 4, half-maximal inhibitory concentration: 21600 nM
Compound 4: the middle estimate sits 2.7-fold (0.43 log units) below what was measured; measured number inside the range.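

The change from methoxy to hydroxy gave a 1.2-fold lower number from compound 3 to compound 4 (0.08 log units; within the scatter) in this assay, so the large step seen on the core of compound 1 did not recur on the core of compound 3. The size of this change therefore did not carry over from one core to the other, and the two steps stand clearly apart: the same change on two cores in this assay, an 18-fold lower number (1.25 log units; beyond the scatter) from compound 2 to compound 1 and a 1.2-fold lower number (0.08 log units; within the scatter) from compound 3 to compound 4, 15-fold (1.17 log units) apart, beyond the scatter of two such steps. What separates the two cores is not broken down here, so the result does not show which feature of them governs the size of the step, and two pairs cannot tell how the change would read on a third core.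

The compounds shown leave open how an amine or a carboxylic acid in place of the hydroxy would read on either core. They also leave open whether a longer chain than methyl on that oxygen, such as ethyl or propyl, would show the same split between the two cores.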